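The compounds below may be only part of what the source reports. "The series", "measured", "known", "first", "only" and "open" are said of these compounds alone.

The measured compounds are:
compound 1, `COc1cc(/C=C/c2cc(=O)c3c(OC)cc(OC)cc3o2)cc(OC)c1`, giving 23700 nM in a functional assay on SKHep cells (Homo sapiens) for antiproliferative activity, read by MTT assay, with a stated time of 12 h; on this read-out lower numbers stand for stronger inhibition and higher numbers for weaker inhibition;
compound 2, `COc1cc(OC)c2c(=O)cc(/C=C/c3ccc(C(F)(F)F)cc3)oc2c1`, giving 20600 nM in this assay;
compound 3, `COc1cc(OC)c2c(=O)cc(/C=C/c3ccc(F)cc3)oc2c1`, giving 29200 nM in this assay.

Compound 3 gives the highest of the three numbers, but its gaps to compound 1 and to compound 2 both lie within the scatter, so the three measured compounds cannot be told apart in this assay. Compound 4, `COc1cc(OC)c2c(=O)cc(/C=C/c3ccc([N+](=O)[O-])cc3)oc2c1`, has not yet been measured. It differs from compound 3 in one place: nitro in place of fluoro on an aromatic carbon. For the measured compounds named here, one measured step bears on the same aromatic carbon, a 1.4-fold higher number from compound 2 to compound 3 (0.15 log units; within the scatter), which exchanged one group for another there without moving the number beyond the scatter. Going by the values given here, no other measured pair touches this part of the shared core, and the nitro group appears in none of the measured compounds, so its own contribution cannot be read from any step. Resting on that single related step, the account expects compound 4 to stay close to compound 3 in this assay, with no step beyond the scatter. Compound 4 is therefore estimated at 25000 nM, with a range from 10000 nM to 60000 nM. The step this estimate implies is a 1.2-fold lower number from compound 3 to compound 4 (0.07 log units; within the scatter), expected to be small.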

Compound 4, half-maximal inhibitory concentration: 22000 nM
Compound 4: middle estimate off by 1.1-fold (0.06 log units), on the high side; the range from low to high includes it.
By their numbers in this assay, from the lowest: compounds 2, 4, 1 and 3 (each within the scatter of the next).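

In this assay, nitro now joins trifluoromethyl and fluoro as a third group on this aromatic carbon, and placing it there gives two further steps, one against fluoro (a 1.3-fold lower number from compound 3 to compound 4 (0.12 log units; within the scatter)) and one against trifluoromethyl (a 1.1-fold higher number from compound 2 to compound 4 (0.03 log units; within the scatter)). The earlier compounds shown here offered a single exchange at this place, whereas compound 2, compound 3 and compound 4 now form a set of three in which no step leaves the scatter, even though nitro brings 3 heavy atoms and 2 hydrogen-bond acceptors where fluoro has 1 heavy atom and 0 hydrogen-bond acceptors. Among these three groups, then, the number does not distinguish one from another, and nothing measured here speaks to why that is so.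

The compounds shown leave open whether an amine, a hydroxyl or a carboxylic acid on this same aromatic carbon would move the number beyond the scatter, or whether the flat result holds only for the three groups seen so far. They also leave open whether nitro, fluoro or trifluoromethyl would behave alike on another carbon of the same ring.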